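The source may report more compounds than this note shows. Statements on the series, on what has been measured and on what is new or still open speak of the compounds shown alone.

Compound 1, `CCCC(O)C#CC#CCO`: > 50000 nM
Compound 2, `CCCCCC(O)C#CC#CC(O)CCC`: 19000 nM
Compound 3, `CCCCC[C@H](O)C#CC#CCO`: > 100000 nM

In a toxicity assay on Hepa-1c1c7 cells (Mus musculus) for inhibition (a higher number here means a weaker inhibitor, a lower number a stronger inhibitor), compound 1 gives only a limit, > 50000 nM, which is the limit of > 50000 nM in this assay, at which 1 of the 3 values shown sits. Compound 2 gives a number, 19000 nM. The change pentyl in place of hydrogen on a saturated chain carbon bound to an oxygen on a saturated carbon and a triple-bonded carbon brought an at least 2.6-fold lower number from compound 1 to compound 2 (0.42 log units; beyond the scatter).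

For compound 3 the result in this assay is again only a limit, > 100000 nM, namely (the limit of > 100000 nM in this assay, at which 1 of the 3 values shown sits). How the core of compound 3 differs from the core of compound 1 is not broken down here.

Compound 4, `CCCCC[C@H](O)C#CC#C[C@@H](O)CCCCC`, has not yet been measured in this assay. It arises from compound 3 by pentyl in place of hydrogen on a saturated chain carbon bound to an oxygen on a saturated carbon and a triple-bonded carbon, the same change that turned compound 1 into compound 2. The step of an at least 6.6-fold lower number from compound 3 to compound 4 (0.82 log units; beyond the scatter) is expected, resting on the earlier step of an at least 2.6-fold lower number from compound 1 to compound 2 (0.42 log units; beyond the scatter). Compound 4 is estimated at 15000 nM, likely between 4000 nM and 60000 nM.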

Compound 4, half-maximal inhibitory concentration: 47000 nM
Compound 4: the middle estimate sits 3.1-fold (0.50 log units) below what was measured, within the range that was stated.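

In this assay, pentyl in place of hydrogen on a saturated chain carbon bound to an oxygen on a saturated carbon and a triple-bonded carbon gave an at least 2.1-fold lower number from compound 3 to compound 4 (0.32 log units; beyond the scatter), so this change lowered the number on a second core as well. Compound 3 gives only a limit, > 100000 nM. The direction therefore carries over between these two cores, but the size of the effect is not pinned down, and whether it is the same on both remains unknown: the same change on two cores in this assay, an at least 2.6-fold lower number (0.42 log units; beyond the scatter) from compound 1 to compound 2 and an at least 2.1-fold lower number (0.32 log units; beyond the scatter) from compound 3 to compound 4; the limit leaves it open whether they differ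

The compounds shown leave open what a longer chain, an amine or a carboxylic acid in place of the pentyl would do in this assay. They also leave open whether the change would act the same way on any further core.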